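Side chain swap on a shared core

The source may hold more compounds than are shown below. What is called first, only, known or untested is meant among the compounds shown, and "the series" means these compounds.

Compound 1 `O=C1c2c[n+]([O-])c3ccccc3c2C(=O)c2c1c1ccccc1n2Cc1cn(CC(O)CO)nn1` gives 880 nM
Compound 2 `O=C1c2c[n+]([O-])c3ccccc3c2C(=O)c2c1c1ccccc1n2CCN1CCCC1` gives 410 nM
Compound 3 `CCCN1CCN(CCCCn2c3c(c4ccccc42)C(=O)c2c[n+]([O-])c4ccccc4c2C3=O)CC1` gives 320 nM

All three values come from a functional assay on A549 cells (Homo sapiens) for cytotoxicity, read by MTT assay, with a stated time of 72 h (a lower number here means a stronger inhibitor, a higher number a weaker inhibitor), and compound 4 `CN1CCN(CCCCCn2c3c(c4ccccc42)C(=O)c2c[n+]([O-])c4ccccc4c2C3=O)CC1` is still to be measured there. Compound 3 stands level with compound 2, as the move a 1.3-fold lower number from compound 2 to compound 3 (0.11 log units; within the scatter) stays within the scatter. Compound 1 lies further off, with a 2.8-fold lower number from compound 1 to compound 3 (0.44 log units; beyond the scatter) beyond the scatter, and the other step from it, a 2.1-fold lower number from compound 1 to compound 2 (0.33 log units; beyond the scatter), is also modest.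

The change to compound 4 is (4-methylpiperazin-1-yl)methyl in place of 4-propylpiperazin-1-yl on a saturated chain carbon, four bonds along the chain from an aromatic nitrogen on a saturated chain carbon, four bonds along the chain from an aromatic nitrogen. Cut one bond further out, 3-(4-propylpiperazin-1-yl)propyl gives way to 4-(4-methylpiperazin-1-yl)butyl. Within the data shown here, no measured pair shows this swap on its own. The two steps from compound 1 replace its triazole-bearing group, which is a different kind of change. The closest guide is the move from compound 2 to compound 3, where replacing the whole end of the side chain gave only a 1.3-fold lower number from compound 2 to compound 3 (0.11 log units; within the scatter) as a shift. No step beyond the scatter is therefore expected in this assay for this smaller edit.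

The expected change is a 1.1-fold higher number from compound 3 to compound 4 (0.04 log units; within the scatter) and would sit within the scatter. For compound 4 the estimated value is 350 nM with an expected range from 160 nM to 800 nM in this test.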

Compound 4, half-maximal inhibitory concentration: 870 nM
Estimate against measurement, compound 4: 2.5-fold (0.40 log units) below, outside the stated range (above it).
By their numbers in this assay, from the lowest: compounds 3 and 2 (each within the scatter of the next); then compounds 4 and 1 (each within the scatter of the next).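

Among these compounds, the end of the side chain proved less forgiving than the earlier compounds suggested: in this assay, the edit from 3-(4-propylpiperazin-1-yl)propyl to 4-(4-methylpiperazin-1-yl)butyl gives a 2.7-fold higher number from compound 3 to compound 4 (0.43 log units; beyond the scatter), whereas the larger-looking replacement between compound 2 and compound 3 stayed within the scatter. Compound 4 also separates from the pyrrolidine-bearing compound, with a 2.1-fold higher number from compound 2 to compound 4 (0.33 log units; beyond the scatter), so a piperazine end does not by itself keep the number low at this position. The triazole-bearing compound, once clearly apart from the other two, now has a match, with a 1.0-fold lower number from compound 1 to compound 4 (0.00 log units; within the scatter), which shows that very different side chains can give the same cell result here.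

No measurement shown explains why this small edit moves the number. The edit shortens the group on the piperazine and lengthens the chain at once, so a 4-(4-propylpiperazin-1-yl)butyl group, or a 3-(4-methylpiperazin-1-yl)propyl group at the same place, would be needed to tell which of the two changes carries the shift.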